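The source may hold more compounds than are shown below. What is called first, only, known or untested is meant among the compounds shown, and "the series" means these compounds.

Measured in an ADME assay on CHO cells (Cricetulus griseus) for cytotoxicity, read by LDH release; on this read-out lower numbers stand for stronger inhibition and higher numbers for weaker inhibition:

- Compound 1 `CC(Oc1ccc(Cl)cc1Cl)C(=O)N[C@H](C)c1ccc(F)cc1`: 97000 nM
- Compound 2 `CC(Oc1ccc(Cl)cc1Cl)C(=O)NOCc1ccc(F)cc1`: 59000 nM
- Compound 3 `CC(Oc1ccc(Cl)cc1Cl)C(=O)NCc1cccc(F)c1`: 27000 nM

Of these three, compound 3 gives the lowest number, and its gaps to compound 1 and compound 2 both lie beyond the usual scatter. Compound 4 `Cc1ccccc1CNC(=O)C(C)Oc1ccc(Cl)cc1Cl` has 2-methylphenyl in place of 3-fluorophenyl on a saturated chain carbon bound to an amide-type nitrogen. Within the data shown here, no two measured compounds differ in one place only, so the data offer no direct guide to this swap. In this assay, a small move toward a higher number is expected, perhaps none beyond the scatter. The expected step is a 1.4-fold higher number from compound 3 to compound 4 (0.15 log units; within the scatter). For compound 4 the estimated value is 38000 nM, with an expected range from 15000 nM to 95000 nM.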

Compound 4, half-maximal inhibitory concentration: > 100000 nM
Compound 4: a limit, no number (the forecaster's own chance of this, stated with the estimate: 12%); middle value at least 2.6-fold (0.42 log units) from the limit.
By their numbers in this assay, from the lowest: compound 3; then compounds 2 and 1 (each within the scatter of the next). At a limit, above all of these: compound 4.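

In this assay, 2-methylphenyl in place of 3-fluorophenyl gives an at least 3.7-fold higher number from compound 3 to compound 4 (0.56 log units; beyond the scatter). Both groups hold the same number of heavy atoms and one aromatic ring of carbon only, yet the read-out still shifts clearly, so this position responds to what the ring carries. Compound 4 stands at a limit of the assay rather than at a number, so the full size of the step stays unknown: the limit of > 100000 nM in this assay, at which 1 of the 4 values shown sits.

From the compounds shown here alone, whether the added methyl or the lost fluorine drives the shift remains open, since both change in this one swap. Going by these compounds, how a plain phenyl or a pyridyl group would read at this place also remains open.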